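Thiazole ketone series: methoxy for chloro on the aryl

This account rests on a few compounds, and the source may have more. Where it says the series, first, only, none or still open, it means among the compounds named here.

Two compounds of this series have numbers in a functional assay on U-87MG ATCC cells for antiproliferative activity against U-87 MG (Homo sapiens), read by MTT assay, with a stated time of 48 h, tested at 50 uM (on this read-out lower numbers stand for a stronger effect and higher numbers for a weaker effect at the one concentration tested), so far. Compound 1 `COc1ccc(-c2nc(C)c(C(=O)CSc3nc(-c4cccc(OC)c4)c(C#N)c(=O)[nH]3)s2)cc1` gives 43.2% in this assay. Compound 2 `Cc1nc(-c2ccc(Cl)cc2)sc1C(=O)CSc1nc(-c2cccc(Cl)c2)c(C#N)c(=O)[nH]1` gives 52.6% in this assay, which is the higher of the two numbers; the gap to compound 1 lies within the scatter, so no order between the two can be read from it.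

Compound 3 `COc1ccc(-c2nc(C)c(C(=O)CSc3nc(-c4cccc(Cl)c4)c(C#N)c(=O)[nH]3)s2)cc1` is the next member. It differs from compound 2 at one place: methoxy in place of chloro on an aromatic carbon. The change sits on an aromatic carbon of a six-membered aromatic ring of carbon only. Compound 1 carries the methoxy at this place as well and its number is not separated from compound 2 beyond the scatter, so for this assay the step from compound 2 to compound 3 is expected to be small, a number 4.6 percentage points lower from compound 2 to compound 3 (within the scatter), if anything toward a lower number. The estimate for compound 3 in this assay is 48%, within 35% to 60%.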

Compound 3, a percentage reported as activity, at one concentration (the size of the read-out at that concentration, not a potency): 83.4%
The estimate for compound 3 lay 35.4 percentage points below the measured number, and the stated range ends below it.
By their numbers in this assay, from the lowest: compounds 1 and 2 (each within the scatter of the next); then compound 3.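

In this assay the place para to a large group is not a silent one: methoxy in place of chloro there gives a number 30.8 percentage points higher from compound 2 to compound 3 (beyond the scatter) and so a weaker effect at the one concentration tested. On the other aromatic ring, chloro in place of methoxy gives a number 40.2 percentage points higher from compound 1 to compound 3 (beyond the scatter) and likewise a weaker effect, so compound 3, with one methoxy and one chloro, stands apart in both of its one-place steps. Within these three compounds, the result of a swap at one ring may therefore depend on the group on the other ring. Nothing at hand bears on the reason for these steps.

Open, as far as these compounds go, is how the fourth pairing, the 4-chlorophenyl with methoxy on the other ring, would read. Also open, from the compounds shown here alone, is how an amine or a carboxylic acid would read at the place para to a large group.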